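Trifluoromethyl for fluoro on the fused ring: expected stability

A few compounds are considered here, and "the series" means these few. Any claim that something is new, unique, unknown or untested is made for them only; others in the source may bear on it.

Measured compounds:
Compound 1, `Fc1cc(C(F)(F)F)ccc1-c1ccc(Cn2nnc3ccccc32)cc1`: 0.1 mL/min/g
Compound 2, `Fc1cc(Cl)ccc1-c1ccc(Cn2nnc3c(F)cccc32)cn1`: 0.1 mL/min/g
Compound 3, `Fc1ccc2c(c1)nnn2Cc1ccc(-c2ccc(Cl)cc2F)nc1`: 0.1 mL/min/g

In an ADME assay on microsomes from liver (Homo sapiens) for metabolic stability, tested at 2.5 uM (on this read-out lower numbers stand for slow clearance and higher numbers for fast clearance), compound 2 gives 0.1 mL/min/g, level at the digits shown with compound 1 at 0.1 mL/min/g and with compound 3 at 0.1 mL/min/g. All three lie within the usual scatter of one another, so no order among them can be read. Compound 4, `Fc1cc(Cl)ccc1-c1ccc(Cn2nnc3c(C(F)(F)F)cccc32)cn1`, is not yet measured in this assay. It differs from compound 2 in one place: trifluoromethyl in place of fluoro on an aromatic carbon. Among the measured compounds shown here, no measured pair shows this change. Compound 1, which carries a trifluoromethyl group on a different ring, gives 0.1 mL/min/g in this assay, and every measured value sits at the same low level. The step is therefore expected to be none beyond the scatter, no change at the digits printed from compound 2 to compound 4 (within the scatter). Compound 4 is expected to give about 0.1 mL/min/g, with a range from 0.05 mL/min/g to 0.3 mL/min/g.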

Compound 4, intrinsic clearance in a liver preparation (reported as CLH), per the amount of preparation that the assay uses: 0.04 mL/min/g
For compound 4 the middle estimate is 2.5-fold (0.40 log units) above the measured one; the measured number lies below the stated range.
By their numbers in this assay, from the lowest: compound 4; then compounds 1, 2 and 3 (each within the scatter of the next).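

At this aromatic carbon of the fused system, trifluoromethyl in place of fluoro gives a 2.5-fold lower number from compound 2 to compound 4 (0.40 log units; beyond the scatter) in this assay and so moves the read-out further down. Among the compounds shown here, the earlier compounds offered no one-place pair and could not be ordered, so this is the first step beyond the scatter among them, though a modest one. Nothing measured here accounts for the step. The compounds shown leave open how a methoxy group, a nitrile or an amine at this carbon would compare, and whether the same change on another ring gives a similar step.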